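2,4-dihydroxyphenyl to 2-hydroxyphenyl: the step to compound 3

The compounds below may be only part of what the source reports. "The series", "measured", "known", "first", "only" and "open" are said of these compounds alone.

In an ADME assay on MT4 cells (Homo sapiens) for cytotoxicity, read by MTT assay, with a stated time of 4 days (a higher number here means that more compound is tolerated, a lower number that less compound is tolerated), compound 1 (`C/C(=N\NC(=O)COc1cccc2ccccc12)c1cccc([N+](=O)[O-])c1`) gives 12.1 ug/mL while compound 2 (`C/C(=N\NC(=O)COc1cccc2ccccc12)c1ccc(O)cc1O`) gives 59.9 ug/mL as the highest of the two numbers. Compound 3 (`C/C(=N\NC(=O)COc1cccc2ccccc12)c1ccccc1O`) differs from compound 2 by hydrogen in place of hydroxy on an aromatic carbon. Going by the values given here, the one measured step is a 5.0-fold higher number from compound 1 to compound 2 (0.69 log units; beyond the scatter) on exchanging 3-nitrophenyl for 2,4-dihydroxyphenyl, and it bears on this change only loosely. Among the compounds with values here, with that step as the sole guide, the expected move is modest and toward a lower number, estimated as a 2.1-fold lower number from compound 2 to compound 3 (0.33 log units; beyond the scatter) in this assay here. The expected value for compound 3 is 28 ug/mL (estimated range 10 ug/mL to 70 ug/mL).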

Compound 3, half-maximal cytotoxic concentration: 11.3 ug/mL
Compound 3: the middle estimate sits 2.5-fold (0.39 log units) above what was measured, and the stated range covers the measured number.
By their numbers in this assay, from the lowest: compounds 3 and 1 (each within the scatter of the next); then compound 2.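

In this assay, the hydroxy para to a large group makes a clear difference on its own: a 5.3-fold lower number from compound 2 to compound 3 (0.72 log units; beyond the scatter). The higher number of compound 2 therefore depends on this hydroxy, and the remaining 2-hydroxy group does not preserve it. Without the hydroxy, the 2-hydroxyphenyl and 3-nitrophenyl groups cannot be told apart, with a 1.1-fold lower number from compound 1 to compound 3 (0.03 log units; within the scatter).

From the compounds shown here alone, whether a methoxy or an amine at this position would keep the higher number of compound 2 remains open, as does the need for the 2-hydroxy group. No measurement here explains either step.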